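The compounds below may be only part of what the source reports. "The series", "measured", "known", "first", "only" and "open" are said of these compounds alone.

Compound 1 `C=CCn1c(=O)n(C2C=CC(CO)O2)c2nc(N)nc(O)c21` was examined in a functional assay (B cells) with Mus musculus as the target (a higher number here means that more compound is needed for the effect, a lower number that less compound is needed), where compound 1 gives 6 uM. For the measured compounds named here, the only other compound measured in this assay is compound 2 `C=CCn1c(=O)n(CCC(CCOCc2ccccc2)CCOCc2ccccc2)c2nc(N)nc(O)c21`, which gives 7 uM. The two numbers lie within the usual scatter of each other, so compound 1 and compound 2 cannot be told apart on these data, even though the groups on the ring nitrogen of the shared core are very different in the two.

Compound 3 `C=CCn1c(=O)n(Cc2ccccc2)c2nc(N)nc(O)c21` has not yet been measured in this assay. It differs from compound 1 by a group of 7 heavy atoms (7 carbon; one six-membered aromatic ring of carbon only) in place of a group of 7 heavy atoms (5 carbon, 2 oxygen; one five-membered non-aromatic ring with 1 hetero atom), on an aromatic nitrogen.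

Going by the values given here, no step between two measured compounds is available to guide the expectation. What the data show is that two quite unlike groups at the same position of the core give nearly the same number, as seen in compound 1 with 6 uM and compound 2 with 7 uM. On that basis the step of a 1.2-fold higher number from compound 1 to compound 3 (0.07 log units; within the scatter) is expected to be small, not beyond the scatter in either direction. Compound 3 is therefore estimated at 7 uM, with a range from 2 uM to 25 uM.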

Compound 3, concentration for half-maximal effect: 5 uM
Beside the measured number, compound 3's estimate is 1.4-fold (0.15 log units) above it, within the range that was stated.
By their numbers in this assay, from the lowest: compounds 3, 1 and 2 (each within the scatter of the next).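

In this assay, for the compounds shown here, putting benzyl in place of the group with the five-membered non-aromatic ring, on the aromatic nitrogen of the five-membered aromatic ring, gives a 1.2-fold lower number from compound 1 to compound 3 (0.08 log units; within the scatter), the first step at this position that can be read directly. The group that leaves has 2 oxygen atoms, 1 hydrogen-bond donor and 2 hydrogen-bond acceptors, while benzyl has only carbon atoms and 0 of either, so in this one pair, the loss of these features and the exchange of the non-aromatic ring for a six-membered aromatic ring leave the number within the scatter. Nothing measured alongside this result explains it.

Going by these compounds, whether an amine, a carboxylic acid or a single methyl group on this nitrogen would give a step beyond the scatter remains open. The allyl group is the same in all three compounds, so the effect of a propyl group or a longer chain in its place is also unknown.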